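A Chlorophenyl Swap in a Tolerated Series

The compounds below may be only part of what the source reports. "The series", "measured", "known", "first", "only" and "open" are said of these compounds alone.

Of the compounds shown here, three have so far been read in a toxicity assay on MT2 cells (Homo sapiens) for cytotoxicity, read by XTT assay, with a stated time of 4 days; a lower number here means that less compound is tolerated, a higher number that more compound is tolerated. There, compound 1 `Cc1ccc(-c2ccc(C(=O)N[C@H](c3nc(C)c(CO)s3)[C@@H]3CCCCN3)[nH]2)cc1F` gives 16100 nM, compound 2 `Cc1ccc(-c2ccc(C(=O)N[C@H](c3nc(C)c(CCO)s3)[C@@H]3CCCCN3)[nH]2)cc1F` gives 29700 nM and compound 3 `Cc1ccc(-c2ccc(C(=O)N[C@@H](c3nc(C)c(CCO)s3)[C@@H]3CCCCN3)[nH]2)cc1F` gives 21200 nM. Compound 2 therefore stands within the scatter of both others.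

Two measured steps lead to or from compound 2. Hydroxymethyl in place of hydroxy on a saturated chain carbon gives a 1.8-fold higher number from compound 1 to compound 2 (0.27 log units; within the scatter). A single stereocentre gives a 1.4-fold lower number from compound 2 to compound 3 (0.15 log units; within the scatter), a comparison that rests on (the fact that compounds 2 and 3 differ only in the configuration as drawn).

The next compound, compound 4 `Cc1nc([C@@H](NC(=O)c2ccc(-c3ccc(Cl)cc3)[nH]2)[C@@H]2CCCCN2)sc1CCO`, departs from compound 2 elsewhere: 4-chlorophenyl in place of 3-fluoro-4-methylphenyl on an aromatic carbon. In words, 4-chlorophenyl stands in place of 3-fluoro-4-methylphenyl on an aromatic carbon of a five-membered aromatic ring with 1 nitrogen. Among the measured compounds shown here, neither measured step touches this place, so they offer only indirect guidance, and no measured step tests the aryl group itself. Both stayed within the scatter, so no step beyond the scatter is expected in this assay. The estimate is a 1.4-fold lower number from compound 2 to compound 4 (0.13 log units; within the scatter), which is expected to remain within that scatter. For compound 4 the expected value is 22000 nM, with an estimated range from 9000 nM to 50000 nM.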

Compound 4, half-maximal cytotoxic concentration: 26800 nM
For compound 4 the middle estimate is 1.2-fold (0.09 log units) below the measured one; the range from low to high includes it.
By their numbers in this assay, from the lowest: compounds 1, 3, 4 and 2 (each within the scatter of the next).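

In this assay, replacing 3-fluoro-4-methylphenyl with 4-chlorophenyl on an aromatic carbon of a five-membered aromatic ring with 1 nitrogen gives a 1.1-fold lower number from compound 2 to compound 4 (0.04 log units; within the scatter). Among the compounds shown here, this is the first measured step at this position, since the earlier steps changed only the chain bearing the hydroxy group and one stereocentre, and it shows that a change of aryl group here, with one heavy atom fewer and chlorine in place of fluorine and methyl, also leaves the reading within the scatter, so that the four compounds now form a series in which each lies within the scatter of the next. For the compounds shown here, the only information available concerns the configuration of compounds 2 and 3 and does not bear on this aryl change, so no cause can be given for the result.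

Both aryl groups shown carry a halogen, so it remains open whether an unsubstituted phenyl, or a phenyl bearing an amine or a carboxylic acid, would read the same at this position. From the compounds shown here alone, it also remains open whether 4-chlorophenyl would read the same when combined with the other configuration drawn in compound 3.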